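Trading methyl for methoxy in compound 3

The compounds below may be only part of what the source reports. "The series", "measured", "known", "first", "only" and "open" are said of these compounds alone.

compound 1 `O=C(NO)c1ccc(/C=C/c2ccnc(-c3cc(F)ccc3O)c2)cc1`: 2040 nM
compound 2 `COc1ccccc1-c1cc(/C=C/c2ccc(C(=O)NO)cc2)ccn1`: 8440 nM
compound 3 `Cc1ccc(-c2cc(/C=C/c3ccc(C(=O)NO)cc3)ccn2)cc1`: 2390 nM

In a functional assay on HCT-116 cells (Homo sapiens) for antiproliferative activity, read by CellTiter-Glo, with a stated time of 72 h (a lower number here means a stronger inhibitor, a higher number a weaker inhibitor), compound 3 gives 2390 nM. That places it level with compound 1, as the data show a 1.2-fold higher number from compound 1 to compound 3 (0.07 log units; within the scatter). Only compound 2 stands clearly apart.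

Compound 4 `COc1ccc(-c2cc(/C=C/c3ccc(C(=O)NO)cc3)ccn2)cc1` alters a single group of compound 3: methoxy in place of methyl on an aromatic carbon. This puts methoxy in place of methyl on an aromatic carbon, para to a large group, turning 4-methylphenyl into 4-methoxyphenyl.

Among the measured compounds shown here, no measured step makes exactly this swap. The closest is a 3.5-fold lower number from compound 2 to compound 3 (0.55 log units; beyond the scatter), but there 2-methoxyphenyl gives way to 4-methylphenyl, so the group and its place both differ. That modest step marks roughly the largest change to expect. The swap from 5-fluoro-2-hydroxyphenyl, a 1.2-fold higher number from compound 1 to compound 3 (0.07 log units; within the scatter), suggests that a change on this ring can also leave this assay almost unmoved. The expected result is a 1.2-fold higher number from compound 3 to compound 4 (0.07 log units; within the scatter), a small step with no firm direction. For compound 4 the estimate is 2800 nM, with an expected range from 1200 nM to 6500 nM.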

Compound 4, half-maximal inhibitory concentration: 3560 nM
For compound 4 the middle estimate is 1.3-fold (0.10 log units) below the measured one, and the stated range covers the measured number.
By their numbers in this assay, from the lowest: compounds 1, 3 and 4 (each within the scatter of the next); then compound 2.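

The direct reading of this swap in this assay is a 1.5-fold higher number from compound 3 to compound 4 (0.17 log units; within the scatter) and so methyl and methoxy at this place cannot be told apart, while a 1.7-fold higher number from compound 1 to compound 4 (0.24 log units; within the scatter) shows that 4-methoxyphenyl also reads level with 5-fluoro-2-hydroxyphenyl. Where the methoxy sits on the ring does count: 4-methoxyphenyl in place of 2-methoxyphenyl gives a 2.4-fold lower number from compound 2 to compound 4 (0.37 log units; beyond the scatter) and that modest step lies beyond the scatter, even though the group itself stays the same. Nothing given here explains these numbers.

The compounds shown leave open how an amine or a carboxylic acid at this same place would read in this assay and whether either would break from the level seen so far. They also leave open whether a longer chain, such as ethoxy, would stay level with methyl and methoxy.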